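Removing One Methyl From the Diamino Core: Cytotoxicity Expectation

The compounds below may be only part of what the source reports. "The series", "measured", "known", "first", "only" and "open" are said of these compounds alone.

The starting point is compound 1, `Cc1cc(C)c(Oc2cc(Nc3ccc(C#N)cc3)c(N)cc2N)c(C)c1`, whose tolerance by the cells is measured in an ADME assay on H9 cells (Homo sapiens) for cytotoxicity, read by XTT assay, with a stated time of 6 days (a higher number here means that more compound is tolerated, a lower number that less compound is tolerated), where compound 1 gives 50000 nM. Two related compounds carry nitro groups in place of the two amines. Compound 2, `Cc1cc(C)c(Oc2cc(Nc3ccc(C#N)cc3)c([N+](=O)[O-])cc2[N+](=O)[O-])c(C)c1`, in this assay reaches only a limit of the assay, > 59800 nM, and not a number. Compound 3, `Cc1cccc(C)c1Oc1cc(Nc2ccc(C#N)cc2)c([N+](=O)[O-])cc1[N+](=O)[O-]`, likewise gives only a limit in this assay, > 61800 nM. How the core of compound 1 differs from that of compound 2 is not broken down here.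

From compound 2 to compound 3 the change is hydrogen in place of methyl on an aromatic carbon, and the step it made, a step that the two limits leave unreadable from compound 2 to compound 3, cannot be read because both values are limits, as the limit of > 59800 nM in this assay, at which 1 of the 3 values shown sits, and the limit of > 61800 nM in this assay, at which 1 of the 3 values shown sits, show. The change from compound 1 to the still unmeasured compound 4, `Cc1cccc(C)c1Oc1cc(Nc2ccc(C#N)cc2)c(N)cc1N`, is hydrogen in place of methyl on an aromatic carbon, the same change at the same place.

For the measured compounds named here, since the one measured instance of this change is unreadable, the expectation for compound 4 rests only on the value of compound 1, 50000 nM, with no shift assumed. Compound 4 is therefore expected to show a step of no change at the digits printed from compound 1 to compound 4 (within the scatter) in this assay. Compound 4 is estimated at 50000 nM, expected to fall between 25000 nM and 100000 nM.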

Compound 4, half-maximal cytotoxic concentration: 53200 nM
The estimate for compound 4 lay 1.1-fold (0.03 log units) below the measured number; low and high end bracket the measured number.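

In this assay, going from 2,4,6-trimethylphenyl to 2,6-dimethylphenyl on the core of compound 1 gives a 1.1-fold higher number from compound 1 to compound 4 (0.03 log units; within the scatter), so the two compounds cannot be told apart by how well the cells tolerate them. On the core with two nitro groups, compound 2 gives only a limit of the assay and not a number: the limit of > 59800 nM in this assay, at which 1 of the 4 values shown sits. Compound 3, which carries the same change on that core, gives > 61800 nM, likewise a limit and not a number, so the step on that core cannot be read, and this single readable instance shows neither that the change carries from one core to the other nor that it does not.

The compounds shown leave open how the core of compound 1 would respond at this place to a group other than methyl or hydrogen, such as an ethyl group, a methoxy group or a chlorine atom. They also leave open where a core with one amine and one nitro group, or with an acetamide in place of an amine, would fall in this assay.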